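Anilino to ureido: compound 2 to compound 4

The source may hold more compounds than are shown below. What is called first, only, known or untested is meant among the compounds shown, and "the series" means these compounds.

compound 1 `N#Cc1c(O)nc(SCc2nc3ccccc3[nH]2)nc1-c1ccccc1` gives 2.55 nM
compound 2 `N#Cc1c(Nc2ccccc2)nc(SCc2nc3ccccc3[nH]2)nc1-c1ccccc1` gives 4.46 nM
compound 3 `N#Cc1c(Nc2nccs2)nc(SCc2nc3ccccc3[nH]2)nc1-c1ccccc1` gives 5.81 nM

In a functional assay on SK-OV-3 cells (Homo sapiens) for cytotoxicity, read by MTT assay, with a stated time of 3 days (a higher number here means a weaker inhibitor, a lower number a stronger inhibitor), compound 2 stands within the scatter of both others (a 1.7-fold higher number from compound 1 to compound 2 (0.24 log units; within the scatter); a 1.3-fold higher number from compound 2 to compound 3 (0.11 log units; within the scatter)). Compound 4 `N#Cc1c(NC(N)=O)nc(SCc2nc3ccccc3[nH]2)nc1-c1ccccc1` differs from it at one place (carbamoyl in place of phenyl on a nitrogen on an aromatic ring): carbamoyl in place of phenyl on a nitrogen on an aromatic ring. Among the compounds with values here, the closest precedent is the swap of phenyl for 1,3-thiazol-2-yl on that nitrogen (a 1.3-fold higher number from compound 2 to compound 3 (0.11 log units; within the scatter)). The largest step at this position is modest (a 2.3-fold higher number from compound 1 to compound 3 (0.36 log units; beyond the scatter)). Within the data shown here, no measured compound carries ureido, so no direction can be favoured, and a step within the scatter is expected in this assay. The expected step is a 1.0-fold higher number from compound 2 to compound 4 (0.00 log units; within the scatter) on this estimate. The estimated value for compound 4 is 4.5 nM with an expected range of 1.5 nM to 13 nM in repeat measurements.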

Compound 4, half-maximal inhibitory concentration: 6.75 nM
Estimate against measurement, compound 4: 1.5-fold (0.18 log units) below; measured number inside the range.
By their numbers in this assay, from the lowest: compounds 1, 2, 3 and 4 (each within the scatter of the next, the first and the last beyond it).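

In this assay, a ring on this nitrogen proves unnecessary for holding the number: with carbamoyl in place of the aromatic rings, a 1.5-fold higher number from compound 2 to compound 4 (0.18 log units; within the scatter), and a 1.2-fold higher number from compound 3 to compound 4 (0.07 log units; within the scatter). Against hydroxy, ureido behaves like (1,3-thiazol-2-yl)amino, with a 2.6-fold higher number from compound 1 to compound 4 (0.42 log units; beyond the scatter), whereas anilino, in compound 2, stays within the scatter of hydroxy. No data here explain these numbers. As far as these compounds go, whether a plain amine, an acetyl group or a longer chain on this nitrogen would stay in the same range remains open, as does whether the carbamoyl's terminal amine matters.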